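Swapping Isopropoxy for Pyrrolidin-1-yl: What to Expect

The source may report more compounds than this note shows. Statements on the series, on what has been measured and on what is new or still open speak of the compounds shown alone.

In a functional assay for inhibition of sodium/hydrogen exchanger (Oryctolagus cuniculus) (a lower number here means a stronger inhibitor, a higher number a weaker inhibitor), compound 1 `Cc1cc(Cl)c(S(C)(=O)=O)cc1C(=O)N=C(N)N` gives 25 nM. Compound 2 `Cc1cc(Sc2ccccc2Cl)c(S(C)(=O)=O)cc1C(=O)N=C(N)N` gives 14 nM, and compound 3 `Cc1cc(OC(C)C)c(S(C)(=O)=O)cc1C(=O)N=C(N)N` gives 19 nM. Compound 3 thus stands second highest of the three numbers, with the steps of a 1.3-fold lower number from compound 1 to compound 3 (0.12 log units; within the scatter) and a 1.4-fold higher number from compound 2 to compound 3 (0.13 log units; within the scatter) both falling inside the usual scatter. Compound 4 `Cc1cc(N2CCCC2)c(S(C)(=O)=O)cc1C(=O)N=C(N)N` differs from compound 3 by pyrrolidin-1-yl in place of isopropoxy on an aromatic carbon. Within the data shown here, the steps that bear on this exchange at the same aromatic carbon, a 1.8-fold lower number from compound 1 to compound 2 (0.25 log units; within the scatter) and a 1.3-fold lower number from compound 1 to compound 3 (0.12 log units; within the scatter), were both small, so no step beyond the scatter is expected in this assay, in either direction. Compound 4 is therefore estimated at 18 nM, within 7 nM to 50 nM, which would be a step of a 1.1-fold lower number from compound 3 to compound 4 (0.02 log units; within the scatter).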

Compound 4, half-maximal inhibitory concentration: 11 nM
The estimate for compound 4 lay 1.6-fold (0.21 log units) above the measured number, and the stated range covers the measured number.
By their numbers in this assay, from the lowest: compounds 4, 2, 3 and 1 (each within the scatter of the next, the first and the last beyond it).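

In this assay, pyrrolidin-1-yl is the only replacement shown at this aromatic carbon whose step from the chloro group lies beyond the scatter, though modestly (a 2.3-fold lower number from compound 1 to compound 4 (0.36 log units; beyond the scatter)). Its steps from the other two groups stay within the scatter (a 1.7-fold lower number from compound 3 to compound 4 (0.24 log units; within the scatter); a 1.3-fold lower number from compound 2 to compound 4 (0.10 log units; within the scatter)), so this position accepts a five-membered non-aromatic ring without a separable change from isopropoxy or (2-chlorophenyl)sulfanyl. Nothing available explains these numbers. Still open, on these data alone, is how an open-chain amine such as diethylamino, a piperidin-1-yl ring or a carboxylic acid would read at this carbon.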